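The source may hold more compounds than are shown below. What is called first, only, known or untested is meant among the compounds shown, and "the series" means these compounds.

Measured compounds:
- Compound 1 `CN(C)C(=O)c1cccnc1NCCCN1CCN(c2ccccc2OC(F)(F)F)CC1`: 100 nM in a functional assay on aorta for antagonist activity at Alpha-1D adrenergic receptor (Rattus norvegicus); on this read-out higher numbers stand for weaker binding and lower numbers for tighter binding
- Compound 2 `CN(C)C(=O)c1cccnc1NCCCN1CCN(c2ccccc2-c2ncco2)CC1`: 25.1 nM in this assay

Among the measured compounds shown here, of the two numbers so far, compound 2 has the lower one: the step of a 4.0-fold lower number from compound 1 to compound 2 (0.60 log units; beyond the scatter) separates it from compound 1, which holds the only other value. Compound 3 `CN(C)C(=O)c1cccnc1NCCCN1CCN(c2ccccc2C2CC2)CC1` has not yet been measured. It differs from compound 2 in one place: cyclopropyl in place of 1,3-oxazol-2-yl on an aromatic carbon, the new group sitting ortho to a large group on the same six-membered ring of carbon only.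

For the measured compounds named here, only one measured step bears on this change, and only loosely. The step from compound 1 to compound 2 shows that exchanging the group at this position can move the number by a modest amount, but it replaced a different group and gives no direct guide to the cyclopropyl. The expectation for compound 3 is therefore a small step, a 2.0-fold higher number from compound 2 to compound 3 (0.30 log units; within the scatter), toward a higher number with wide uncertainty. The estimate for compound 3 is 50 nM, with a range from 15 nM to 160 nM.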

Compound 3, dissociation constant: 63.1 nM
Compound 3: middle estimate off by 1.3-fold (0.10 log units), on the low side; the range from low to high includes it.
By their numbers in this assay, from the lowest: compound 2; then compounds 3 and 1 (each within the scatter of the next).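

Going from the 1,3-oxazol-2-yl group to cyclopropyl gives a 2.5-fold higher number from compound 2 to compound 3 (0.40 log units; beyond the scatter) in this assay, so this swap on the aromatic carbon costs binding by more than the usual scatter. Compound 2 now stands apart from both other compounds, as the cyclopropyl and trifluoromethoxy groups cannot be told apart here: a 1.6-fold lower number from compound 1 to compound 3 (0.20 log units; within the scatter) is a gap too small to read as a real difference. Nothing available explains why the 1,3-oxazol-2-yl group gives the lowest number.

Cyclopropyl differs from 1,3-oxazol-2-yl in several ways at once, including ring size, aromaticity and hydrogen-bond acceptors, so three compounds cannot show which difference matters. A phenyl ring or a 1,3-thiazol-2-yl ring on the same carbon would help separate these features.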